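This account rests on a few compounds, and the source may have more. Where it says the series, first, only, none or still open, it means among the compounds named here.

Working notes on the series. Compound 1 `Fc1ccc(N2CCN=C2c2ccc(C3=NCCN3c3ccc(F)cc3)cc2)cc1` bears two 4-fluorophenyl groups on the shared core; in an ADME assay on MDCK cells (Canis lupus familiaris) for cytotoxicity, read by MTT assay, with a stated time of 24 h (a higher number here means that more compound is tolerated, a lower number that less compound is tolerated), compound 1 gives 144000 nM. Compound 2 `c1ccc(N2CCN=C2c2ccc(C3=NCCN3)cc2)cc1` bears a single phenyl group on the same core. In this assay compound 2 reaches only a limit of the assay, > 1030000 nM, and not a number. For the measured compounds named here, compound 2 therefore sits at the limit, as the limit of > 1030000 nM in this assay, at which 1 of the 2 values shown sits, records, so no measured step can be drawn from compound 2 to compound 1. Compound 3 `Fc1ccc(N2CCN=C2c2ccc(C3=NCCN3)cc2)cc1` differs from compound 2 by fluoro in place of hydrogen on an aromatic carbon. Going by the values given here, no measured pair shows this change, so its size is unknown. The expected change is an at least 1.7-fold lower number from compound 2 to compound 3 (0.23 log units; that floor lies within the scatter), a small move toward less tolerated compound, likely not beyond the scatter. For compound 3 the expected value in this assay is 600000 nM, with a range from 200000 nM to 1500000 nM, and a fair chance that only a limit is reported.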

Compound 3, half-maximal cytotoxic concentration: > 971000 nM
Compound 3: only a limit was reported (the forecaster's own chance of this, stated with the estimate: 45%); at least 1.6-fold (0.20 log units) between middle value and limit.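

an at least 6.7-fold higher number from compound 1 to compound 3 (0.82 log units; beyond the scatter) in this assay is the first readable step in the series, and it comes with hydrogen in place of 4-fluorophenyl on an amine nitrogen in a ring, the one place where the two compounds differ. For the compounds shown here, compound 3 also gives a limit of the assay and not a number: the limit of > 971000 nM in this assay, at which 1 of the 3 values shown sits. With compound 2 at a limit too, the step for fluoro in place of hydrogen cannot be read, so this change on the aromatic carbon shows only that compound 3 stays at a limit, unlike compound 1.

Going by these compounds alone, whether fluoro moves the number at all remains open, as no pair with this change has two measured values. Also open, going by these compounds, is how a small methyl group or a longer alkyl chain on that ring nitrogen would compare with 4-fluorophenyl.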